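Swapping the chloro benzothiazole for a dimethyl one

A few compounds are considered here, and "the series" means these few. Any claim that something is new, unique, unknown or untested is made for them only; others in the source may bear on it.

Measured compounds:
compound 1, `COc1ccc(-c2cc(C(=O)Nc3nc4ccc(Cl)cc4s3)nc3cc(-c4ccccc4)nn23)cc1`, 5880 nM
compound 2, `COc1ccc(-c2cc(C(=O)Nc3nc4ccc(Cl)cc4s3)nc3cc(-c4ccccc4)nn23)cc1OC`, 9330 nM
compound 3, `COc1cc(-c2cc(C(=O)Nc3nc4ccc(Cl)cc4s3)nc3cc(-c4ccccc4)nn23)cc(OC)c1OC`, 38900 nM

All three were tested in a functional assay on DU-145 cells (Homo sapiens) for cytotoxicity, read by MTT assay, with a stated time of 48 h; on this read-out higher numbers stand for weaker inhibition and lower numbers for stronger inhibition. Compound 3 gives the highest number of the three: the step of a 6.6-fold higher number from compound 1 to compound 3 (0.82 log units; beyond the scatter) and the step of a 4.2-fold higher number from compound 2 to compound 3 (0.62 log units; beyond the scatter) both lie beyond the scatter, so compound 3 is the weakest of the measured set, while compound 1 and compound 2 sit within the scatter of each other, as a 1.6-fold higher number from compound 1 to compound 2 (0.20 log units; within the scatter) shows.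

Compound 4, `COc1cc(-c2cc(C(=O)Nc3nc4cc(C)c(C)cc4s3)nc3cc(-c4ccccc4)nn23)cc(OC)c1OC`, keeps the shared core and the trimethoxyphenyl group of compound 3 but changes the other end of the molecule: 5,6-dimethyl-1,3-benzothiazol-2-yl in place of 6-chloro-1,3-benzothiazol-2-yl on an amide-type nitrogen. Among the measured compounds shown here, none of the measured steps touches this part of the structure; every step so far changed only the methoxy pattern on the phenyl ring. For the measured compounds named here, there is therefore no measured step that bears directly on the change from compound 3 to compound 4, and the expectation can only lean on the value of compound 3 itself.

With no guidance on direction, compound 4 is expected to stay close to compound 3, with a step of about a 1.0-fold higher number from compound 3 to compound 4 (0.01 log units; within the scatter) in this assay. The estimate for compound 4 is 40000 nM, in a range from 13000 nM to 120000 nM.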

Compound 4, half-maximal inhibitory concentration: 3710 nM
Compound 4: middle estimate off by 11-fold (1.03 log units), on the high side; the measured number lies below the stated range.
By their numbers in this assay, from the lowest: compounds 4, 1 and 2 (each within the scatter of the next, the first and the last beyond it); then compound 3.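

In this assay, among the compounds shown here, the far end of the molecule turns out to matter as well as the methoxy pattern: 5,6-dimethyl-1,3-benzothiazol-2-yl in place of 6-chloro-1,3-benzothiazol-2-yl on the amide-type nitrogen gives a 10-fold lower number from compound 3 to compound 4 (1.02 log units; beyond the scatter), a large step at a place that no earlier step touched. The high number of compound 3 therefore does not follow from the 3,4,5-trimethoxyphenyl group alone, since compound 4 carries that same group and gives 3710 nM. Nothing measured here explains why this swap has so large an effect.

The swap removes the chloro and adds two methyl groups in a single step, so the compounds shown cannot tell whether the loss of the chloro or the gain of the methyl groups accounts for the change, a question that a benzothiazole carrying a single methyl, a fluoro or no substituent at all could help to separate. From the compounds shown here alone, it also remains open whether the 5,6-dimethyl-1,3-benzothiazol-2-yl group would give a similar step alongside the 4-methoxyphenyl group of compound 1.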